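This account rests on a few compounds, and the source may have more. Where it says the series, first, only, none or still open, it means among the compounds named here.

The shared core of compound 1 `ClCc1ccc(Cn2cnc3c(Cl)ncnc32)cc1` carries two substituents: a chloromethyl group on a benzene ring and a chlorine atom on the fused two-ring system. Compound 1 was tested in a functional assay on COLO 205 cells (Homo sapiens) for cytotoxicity, read by sulforhodamine B assay, with a stated time of 48 h; on this read-out higher numbers stand for lower toxicity in this test and lower numbers for higher toxicity in this test. In this assay compound 1 gives > 100000 nM, which is a limit of the assay rather than a measured number. The remaining measured compounds place that limit in context. Compound 2 `ClCc1cccc(Cn2cnc3ncnc(Cl)c32)c1` gives 6300 nM in this assay. Compound 3 `ClCc1cccc(Cn2cnc3c(Cl)nc(Cl)nc32)c1` gives > 100000 nM in this assay, again a limit and not a number. Of the three values shown, two sit at the limit of > 100000 nM in this assay, at which 2 of the 3 values shown sit, and compound 1 is among them.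

Compound 4 `ClCc1ccc(Cn2cnc3c(Cl)nc(Cl)nc32)cc1` has not yet been measured. It differs from compound 1 in one place: chloro in place of hydrogen on an aromatic carbon. The same kind of chlorine addition appears in the pair of compound 2 and compound 3, where compound 2 shows a number and compound 3 shows only a limit. On that basis compound 4 is expected to remain at the limit as well, with a step from compound 1 to compound 4 of a step that the limit leaves unreadable from compound 1 to compound 4, none beyond the scatter. The expected result for compound 4 in this assay is 150000 nM, within a range from 40000 nM to 600000 nM.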

Compound 4, concentration lethal to 50% of the cells: > 100000 nM
Compound 4: only a limit was reported; the forecaster's own chance of this, stated with the estimate: 85%; the middle value is on the limit's open side.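

Compound 1 and compound 4 each give only a limit of the assay and not a number, so no step between them can be read: the limit of > 100000 nM in this assay, at which 3 of the 4 values shown sit.

The compounds shown leave open whether chloro in place of hydrogen on an aromatic carbon changes the result in this assay at all, and by how much.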